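The source may hold more compounds than are shown below. What is called first, only, known or untested is meant among the compounds shown, and "the series" means these compounds.

Measured so far:
Compound 1, `CCCCc1ccc(CNCc2ccccc2)c(=O)n1Cc1ccc(-c2ccccc2-c2nn[nH]n2)cc1`: 1 nM
Compound 2, `CCCCNC(=O)NCc1ccc(CCCC)n(Cc2ccc(-c3ccccc3-c3nn[nH]n3)cc2)c1=O`: 10 nM

In a functional assay (aorta) for antagonist activity, with Oryctolagus cuniculus as the target (a lower number here means a stronger inhibitor, a higher number a weaker inhibitor), compound 1 gives 1 nM, the lower of the two numbers. Compound 2 gives 10 nM in this assay, and the step between them, a 10-fold higher number from compound 1 to compound 2 (1.00 log units; beyond the scatter), came with a butylcarbamoyl in place of benzyl on an amine nitrogen.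

Compound 3, `CCCCc1ccc(CNC(=O)N(C)C)c(=O)n1Cc1ccc(-c2ccccc2-c2nn[nH]n2)cc1`, has not been measured. It departs from compound 1 by dimethylcarbamoyl in place of benzyl on an amine nitrogen. Among the measured compounds shown here, the one measured step that bears on this is a 10-fold higher number from compound 1 to compound 2 (1.00 log units; beyond the scatter), where a carbamoyl group likewise replaced the benzyl group on an amine nitrogen. Since the change to compound 3 is of the same kind, a step of comparable size and in the same direction, towards a higher number, is expected: a 12-fold higher number from compound 1 to compound 3 (1.08 log units; beyond the scatter). Compound 3 is therefore estimated at 12 nM, with a plausible range from 3 nM to 50 nM.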

Compound 3, half-maximal inhibitory concentration: 2 nM
Compound 3: the middle estimate sits 6.0-fold (0.78 log units) above what was measured; measured number outside the range, below it.
By their numbers in this assay, from the lowest: compounds 1 and 3 (each within the scatter of the next); then compound 2.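

In this assay the benzyl group on this amine nitrogen can be replaced by dimethylcarbamoyl with a 2.0-fold higher number from compound 1 to compound 3 (0.30 log units; within the scatter), so among these compounds the ring of the benzyl group is not required for a number this low. The carbamoyl groups do not behave alike: there is a 5.0-fold lower number from compound 2 to compound 3 (0.70 log units; beyond the scatter), with dimethylamino in place of butylamino on a carbonyl carbon. Compound 2 and compound 3 both carry a carbamoyl group. No measurement here explains why these two carbamoyl groups differ.

Still open, going by these compounds, is where ethylamino or a morpholine ring on that carbonyl carbon would fall relative to compound 2 and compound 3. Also open, on these data alone, is how an acetyl or a methanesulfonyl group on the amine nitrogen would compare.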